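The compounds below may be only part of what the source reports. "The series", "measured", "known", "first", "only" and "open" are said of these compounds alone.

Compound 2 `COc1ccc(C2CC(c3ccccc3)=NN2C2=NC(=O)/C(=C3\C(=O)Nc4ccccc43)S2)cc1` is the starting point. In a functional assay on cells (Cancer cell lines, Homo sapiens) for cytotoxicity, read by sulforhodamine B assay, with a stated time of 48 h (a lower number here means a stronger inhibitor of growth, a higher number a weaker inhibitor of growth), compound 2 gives 1520 nM. Among the measured compounds this is the second highest number. Compound 1 `O=C1N=C(N2N=C(c3ccccc3)CC2c2ccccc2O)S/C1=C1/C(=O)Nc2ccccc21` sits nearest to it: in this assay compound 1 gives 2050 nM, and the step of a 1.3-fold lower number from compound 1 to compound 2 (0.13 log units; within the scatter) lies within the scatter. Compound 3 `COc1ccc(C2CC(c3ccccc3)=NN2C2=NC(=O)/C(=C3\C(=O)Nc4ccc(Br)cc43)S2)cc1` is furthest away: in this assay compound 3 gives 240 nM, and the step of a 6.3-fold lower number from compound 2 to compound 3 (0.80 log units; beyond the scatter) goes beyond the scatter.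

The move to compound 4 `COc1ccc(C2=NN(C3=NC(=O)/C(=C4\C(=O)Nc5ccccc54)S3)C(c3ccc(OC)cc3)C2)cc1` is methoxy in place of hydrogen on an aromatic carbon. Within the data shown here, of the two measured steps, the one from compound 1 to compound 2 is the closer guide, as it also swaps a small oxygen-bearing group on a phenyl ring hanging off the shared core, and it produced nothing beyond the scatter. The bromo step sits on a different ring and says little here. The expected step is therefore a 1.0-fold lower number from compound 2 to compound 4 (0.01 log units; within the scatter), with no real movement in either direction. Compound 4 is expected to give about 1500 nM in this assay, within a range from 700 nM to 3200 nM.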

Compound 4, concentration for 50% growth inhibition: 100000 nM
For compound 4 the middle estimate is 67-fold (1.82 log units) below the measured one; measured number outside the range, above it.
By their numbers in this assay, from the lowest: compound 3; then compounds 2 and 1 (each within the scatter of the next); then compound 4.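

The phenyl group that stays unchanged across compounds 1, 2 and 3 turns out to be highly sensitive to substitution: in this assay, going from phenyl to 4-methoxyphenyl gives a 66-fold higher number from compound 2 to compound 4 (1.82 log units; beyond the scatter). The same 4-methoxyphenyl group caused no change beyond the scatter when it replaced 2-hydroxyphenyl on a saturated ring carbon, a 1.3-fold lower number from compound 1 to compound 2 (0.13 log units; within the scatter), so the effect of this group depends on where it is placed in these compounds. Nothing available here explains the large loss of growth inhibition.

As far as these compounds go, it remains open whether a smaller group such as fluoro or methyl would be accepted at this same aromatic carbon, or whether only hydrogen is. Also unresolved is whether the bromo group of compound 3 would recover any of the activity lost in compound 4.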